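Removing the Amino Group from Compound 2

A few compounds are considered here, and "the series" means these few. Any claim that something is new, unique, unknown or untested is made for them only; others in the source may bear on it.

Measured compounds:
Compound 1 `CCOC(=O)c1cnn(C(=O)c2csc(-c3ccccc3)n2)c1N` gives 61.2% in a functional assay on the whole organism (Abdomen, strain Albino) for inhibition, with Mus musculus as the target, with stated times of 50 min and 10 min, at a dose of 25 mg/kg by the oral route; on this read-out lower numbers stand for less inhibition and higher numbers for more inhibition at the one dose given (going by the name of the read-out).
Compound 2 `Nc1nnc(-c2csc(-c3ccccc3)n2)o1` gives 20.3% in this assay.

Compound 2 stands lowest of the two numbers. Its nearest neighbour, compound 1, lies higher by a gap that is beyond the usual scatter, but the two structures differ in several places at once, so that gap cannot be read as a single step and offers no guide to any one change.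

Compound 3 `c1ccc(-c2nc(-c3nnco3)cs2)cc1` differs from compound 2 in one place: hydrogen in place of amino on an aromatic carbon. Within the data shown here, no step between measured compounds covers such a change, so there is no measured precedent to lean on. The step from compound 2 to compound 3 is expected to be small, a number 2.3 percentage points lower from compound 2 to compound 3 (within the scatter), not beyond the scatter in either direction. Compound 3 is therefore estimated to give about 18%, within a range from 4% to 34%.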

Compound 3, a percentage reported as inhibition, in the whole organism at one dose (the size of the read-out at that dose, not a potency): 18.1%
Estimate against measurement, compound 3: 0.1 percentage points below, within the range that was stated.
By their numbers in this assay, from the lowest: compounds 3 and 2 (each within the scatter of the next); then compound 1.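

Among these compounds, the step of a number 2.2 percentage points lower from compound 2 to compound 3 (within the scatter) is the first single change measured at this position, on an aromatic carbon of a five-membered aromatic ring with 2 nitrogen and 1 oxygen. In this assay, then, compound 2 and compound 3 cannot be told apart, so the amino group is not needed at this position to keep the read-out within the scatter of compound 2. Nothing at hand bears on why the two compounds read alike.

The compounds shown leave open what a methyl group, a dimethylamino group or a carboxylic acid on this same aromatic carbon would give in this assay. They also leave open whether hydrogen in place of amino would read the same way on the core of compound 1, which carries an amino group of its own.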